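The source may hold more compounds than are shown below. What is called first, only, known or untested is meant among the compounds shown, and "the series" means these compounds.

Compound 1 `COc1ccc(/C=C/C(=O)c2ccc(OC)c3c2OC(C)(C)C=C3)cc1OCCO`: > 10000 nM, a limit.
Compound 2 `CCC(=O)Oc1cc(/C=C/C(=O)c2ccc(OC)c3c2OC(C)(C)C=C3)ccc1OC`: > 10000 nM, a limit.
Compound 3 `COc1ccc(/C=C/C(=O)Oc2cc(/C=C/C(=O)c3ccc(OC)c4c3OC(C)(C)C=C4)ccc2OC)cc1`: 18000 nM.

Among the compounds with values here, in an ADME assay on L02 cells (Homo sapiens) for cytotoxicity, read by MTT assay (a higher number here means a weaker inhibitor, a lower number a stronger inhibitor), compound 3 gives 18000 nM, the only value in this small set that is a number and not a limit. The other two compounds therefore cannot be ranked against it.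

Compound 4 `COc1ccc(/C=C/C(=O)c2ccc(OC)c3c2OC(C)(C)C=C3)cc1OS(=O)(=O)c1ccc(C)cc1` differs from compound 3 at one place: (4-methylphenyl)sulfonyl in place of (2-(4-methoxyphenyl)ethenyl)carbonyl on an oxygen on an aromatic ring. In words, this is (4-methylphenyl)sulfonyl in place of (2-(4-methoxyphenyl)ethenyl)carbonyl on an oxygen on an aromatic ring.

Two measured steps change the group carried on that same oxygen. One is a step that the limit leaves unreadable from compound 1 to compound 3, and the other is a step that the limit leaves unreadable from compound 2 to compound 3. Neither has a size that can be carried over to the new change, so the evidence for any shift is thin. What remains is the limit of > 10000 nM in this assay, at which 2 of the 3 values shown sit.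

No step beyond the scatter is therefore expected in this assay, in either direction, and this expectation rests mainly on compound 3 at 18000 nM. The expected step is a 1.1-fold lower number from compound 3 to compound 4 (0.05 log units; within the scatter). The estimate for compound 4 is 16000 nM, with an expected range from 7000 nM to 36000 nM. The assay may well report only a limit for it instead of a number.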

Compound 4, half-maximal inhibitory concentration: > 10000 nM
Compound 4: only a limit was reported (the forecaster's own chance of this, stated with the estimate: 45%); the middle value is on the limit's open side.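

In this assay compound 4 gives > 10000 nM, a limit and not a number. The steps to compound 4 from compound 1, compound 2 and compound 3 therefore cannot be read. The compounds shown leave open whether changing the group on that oxygen shifts the value at all, and most results offer no number to compare: the limit of > 10000 nM in this assay, at which 3 of the 4 values shown sit.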